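Aryl change at the carbonyl: notes toward compound 4

The source may report more compounds than this note shows. Statements on the series, on what has been measured and on what is new or still open speak of the compounds shown alone.

Measured in a functional assay on SNB-19 cells (Homo sapiens) for cytotoxicity, read by sulforhodamine B assay, with a stated time of 48 h, tested at 1 uM; a lower number here means a stronger effect, a higher number a weaker effect of the compound at the concentration tested:
compound 1 `COc1cc(-c2cc(/C=C/C(=O)c3ccc(N)cc3)[nH]n2)cc(OC)c1OC` — 79%
compound 2 `COc1ccc(-c2cc(/C=C/C(=O)c3ccc(N)cc3)[nH]n2)cc1OC` — 84%
compound 3 `COc1ccc(-c2cc(/C=C/C(=O)c3cc(OC)c(OC)c(OC)c3)[nH]n2)cc1OC` — 77%

Compound 1 stands second highest of the three numbers in this assay. Its nearest neighbour is compound 3, whose value sits lower by an amount within the scatter; compound 2 sits higher, also within the scatter. Within the data shown here, the one single-point step, a number 5 percentage points higher from compound 1 to compound 2 (within the scatter), is a change on the other aromatic ring and is within the scatter.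

Compound 4 `COc1cc(-c2cc(/C=C/C(=O)c3ccc(F)c(F)c3)[nH]n2)cc(OC)c1OC` differs from compound 1 by 3,4-difluorophenyl in place of 4-aminophenyl on a carbonyl carbon. Among the measured compounds shown here, no measured step touches this position directly. Compounds 1 and 3 differ at the same place and their values lie within the scatter of each other, so a change of the aryl group on the carbonyl carbon has so far not moved the read-out beyond noise. The expected step of a number 1 percentage points lower from compound 1 to compound 4 (within the scatter) is therefore none beyond the scatter. The estimate for compound 4 is 78%, with a range from 64% to 92%.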

Compound 4, a percentage reported as activity, at one concentration (the size of the read-out at that concentration, not a potency): 82%
Estimate against measurement, compound 4: 4 percentage points below; the range from low to high includes it.
By their numbers in this assay, from the lowest: compounds 3, 1, 4 and 2 (each within the scatter of the next).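

In this assay, among these compounds, 3,4-difluorophenyl in place of 4-aminophenyl on a carbonyl carbon gives a number 3 percentage points higher from compound 1 to compound 4 (within the scatter) and provides the first direct reading of a one-place change at this position. The hydrogen-bond donor and acceptor counted on 4-aminophenyl are absent from 3,4-difluorophenyl, yet this exchange does not move the read-out beyond the scatter. No measurement at hand accounts for this result.

The compounds shown leave open whether any group on this carbonyl carbon can move the read-out beyond the scatter, as they include neither a 4-carboxyphenyl nor a non-aromatic amine such as piperidine there. As far as these compounds go, with a single tested concentration, potency differences between compound 1 and compound 4 also remain open.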